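Methoxy to dimethylamino on the core of compound 1

This account rests on a few compounds, and the source may have more. Where it says the series, first, only, none or still open, it means among the compounds named here.

Measured compounds in a functional assay on CEM-DNR-bulk cells (Homo sapiens), read by MTT assay, with a stated time of 72 h; on this read-out lower numbers stand for stronger inhibition and higher numbers for weaker inhibition:
- compound 1 `COc1ncnc2c1c(-c1cccs1)cn2[C@@H]1O[C@H](CO)[C@@H](O)[C@H]1O` gives 12100 nM
- compound 2 `COc1ncnc2c1c(-c1ccccc1)cn2[C@@H]1O[C@H](CO)[C@@H](O)[C@H]1O` gives a limit of the assay, > 20000 nM
- compound 3 `COc1ncnc2c1c(-c1ccco1)cn2[C@@H]1O[C@H](CO)[C@@H](O)[C@H]1O` gives 160 nM

Compound 1 holds the highest of the two numbers reported. Its nearest neighbour is compound 3, reached by a 76-fold lower number from compound 1 to compound 3 (1.88 log units; beyond the scatter). For compound 2 only a limit is known, (the limit of > 20000 nM in this assay, at which 1 of the 3 values shown sits), and the step to it is an at least 1.6-fold higher number from compound 1 to compound 2 (0.21 log units; that floor lies within the scatter). The remaining measured step is an at least 120-fold lower number from compound 2 to compound 3 (2.09 log units; beyond the scatter).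

The next compound is compound 4 `CN(C)c1ncnc2c1c(-c1cccs1)cn2[C@@H]1O[C@H](CO)[C@@H](O)[C@H]1O`. It differs from compound 1 in one place: dimethylamino in place of methoxy on an aromatic carbon. The thiophen-2-yl of compound 1 is kept.

Within the data shown here, none of the measured steps bears on this change: all three alter the group on the aromatic carbon of the five-membered ring, while the methoxy of compound 1 is untouched in every measured compound. There is therefore no basis for expecting a step beyond the scatter in this assay in either direction, and the range of the expectation must be wide.

Compound 4 is expected to give about 15000 nM, within 3000 nM to 60000 nM, which means an expected step of a 1.2-fold higher number from compound 1 to compound 4 (0.09 log units; within the scatter); a result reported only as a limit is a real possibility.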

Compound 4, half-maximal inhibitory concentration: > 20000 nM
Compound 4 ended at the assay's limit; the forecaster's own chance of this, stated with the estimate: 40%; middle value at least 1.3-fold (0.12 log units) from the limit.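

Among these compounds, this is the first reading at the methoxy carbon of the core, as every earlier step changed only the group on the five-membered ring. In this assay, compound 4 gives > 20000 nM, which is a limit of the assay and not a number. The change therefore reads as an at least 1.6-fold higher number from compound 1 to compound 4 (0.21 log units; that floor lies within the scatter): with thiophen-2-yl kept, dimethylamino shows no gain over methoxy, while the size of any loss cannot be read. Limits now account for a sizeable share of this small set: the limit of > 20000 nM in this assay, at which 2 of the 4 values shown sit.

Going by these compounds, it remains open whether dimethylamino would have the same outcome with furan-2-yl kept, the setting in which compound 3 gives 160 nM in this assay. Also open, on these data alone, is how an amino or methylamino group on the same aromatic carbon would compare with methoxy.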